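The compounds below may be only part of what the source reports. "The series", "measured", "known", "first", "only" and "open" are said of these compounds alone.

In a functional assay on NCI-H1581 cells (Homo sapiens) for antiproliferative activity, read by CCK-8 assay, with a stated time of 72 h (a lower number here means a stronger inhibitor, a higher number a weaker inhibitor), two compounds sharing one core have been measured so far. Compound 1 `C=CCN1CCN(c2ccc(C(=O)Nc3n[nH]c4nc(-c5c(Cl)c(OC)cc(OC)c5Cl)ccc34)cc2)CC1` gives 3.3 nM and compound 2 `COc1cc(OC)c(Cl)c(-c2ccc3c(NC(=O)c4ccc(N5CCN(C(C)=O)CC5)cc4)n[nH]c3n2)c1Cl` gives 43.3 nM as the higher of the two numbers. These two differ in one place, acetyl in place of allyl on an amine nitrogen in a ring, and that change is a 13-fold higher number from compound 1 to compound 2 (1.12 log units; beyond the scatter) as a large step well beyond the scatter.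

Compound 3 `COc1cc(OC)c(Cl)c(-c2ccc3c(NC(=O)c4ccc(N(C)CCN(C)C)cc4)n[nH]c3n2)c1Cl` comes from compound 2 through a different change (2-(dimethylamino)ethyl)(methyl)amino in place of 4-acetylpiperazin-1-yl on an aromatic carbon with (2-(dimethylamino)ethyl)(methyl)amino in place of 4-acetylpiperazin-1-yl on an aromatic carbon. Going by the values given here, the single measured step is the only guide, and only a partial one. Among the compounds with values here, compound 3 loses the acetyl, as compound 1 lacks it at 3.3 nM in its own structure, but compound 3 also loses the ring, and no measured compound shows what that does. A lower number than that of compound 2 is therefore expected, by somewhat less than the measured step. The estimate means a 4.8-fold lower number from compound 2 to compound 3 (0.68 log units; beyond the scatter) as the expected step in this assay for now. Compound 3 is expected to read 9 nM with a range of 2.5 nM to 35 nM on this estimate.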

Compound 3, half-maximal inhibitory concentration: 11 nM
Estimate against measurement, compound 3: 1.2-fold (0.09 log units) below, and the stated range covers the measured number.
By their numbers in this assay, from the lowest: compound 1; then compound 3; then compound 2.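

The ring at this position can go without the activity being lost: in this assay, the open chain (2-(dimethylamino)ethyl)(methyl)amino on the aromatic carbon gives a 3.9-fold lower number from compound 2 to compound 3 (0.60 log units; beyond the scatter), a modest step beyond the scatter in favour of the chain over 4-acetylpiperazin-1-yl. The same chain does not match 4-allylpiperazin-1-yl, since the comparison with the allyl ring gives a 3.3-fold higher number from compound 1 to compound 3 (0.52 log units; beyond the scatter), also modest and beyond the scatter, so the open chain takes a middle place and the outcome of replacing a piperazine depends on which piperazine is replaced. Nothing available here explains why these three groups rank in this order.

On these data alone, what stays open is whether the ring itself matters or mainly the group carried at its far nitrogen, a question that a piperazine with a plain methyl on that nitrogen, or a morpholine ring, could help to settle. Also open, as far as these compounds go, is how the length of the chain counts, for instance whether a propyl link between the two nitrogens would read closer to compound 1 or to compound 2.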